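The source may report more compounds than this note shows. Statements on the series, on what has been measured and on what is new or still open speak of the compounds shown alone.

Measured so far in a functional assay on H184B5F5/M10 cells (Homo sapiens) for antiproliferative activity, read by MTT assay, with a stated time of 24 h; a higher number here means a weaker inhibitor, a lower number a stronger inhibitor:
compound 1 `O=C(/C=C/c1ccc(O)cc1)NNC(=O)c1ccccc1` gives 9320 nM;
compound 2 `COc1ccc(C(=O)NNC(=O)/C=C/c2ccc(O)cc2)cc1` gives 8440 nM;
compound 3 `COc1cc(/C=C/C(=O)NNC(=O)c2ccccc2)cc(OC)c1O` is discussed below.

For compound 3 only a limit was recorded in this assay, > 10000 nM, which is a limit and not a number (the limit of > 10000 nM in this assay, at which 1 of the 3 values shown sits). Compound 1 and compound 3 share a hydrazide linker, but how the two cores differ is not broken down here. Compound 2 comes from compound 1 by methoxy in place of hydrogen on an aromatic carbon, which gave a 1.1-fold lower number from compound 1 to compound 2 (0.04 log units; within the scatter). Compound 4 `COc1ccc(C(=O)NNC(=O)/C=C/c2cc(OC)c(O)c(OC)c2)cc1` comes from compound 3 by the same kind of change, (methoxy in place of hydrogen on an aromatic carbon). Because the earlier step was a 1.1-fold lower number from compound 1 to compound 2 (0.04 log units; within the scatter), compound 4 is expected to stay close to compound 3, with an expected step that the limit leaves unreadable from compound 3 to compound 4. Compound 4 is thus estimated at 12000 nM, between 6000 nM and 30000 nM, and quite possibly again only a limit.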

Compound 4, half-maximal inhibitory concentration: 9450 nM
Compound 4: middle estimate off by 1.3-fold (0.10 log units), on the high side; the measured number falls inside the stated range.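

On the core of compound 3, the change from phenyl to 4-methoxyphenyl in this assay gives an at least 1.0-fold lower number from compound 3 to compound 4 (0.02 log units; that floor lies within the scatter). Compound 3 has only a limit, > 10000 nM, so this step is a floor and the real step may be larger. The change stays within the scatter on the core of compound 1, but the data do not show that it carries over to the second core with the same size: the same change on two cores in this assay, a 1.1-fold lower number (0.04 log units; within the scatter) from compound 1 to compound 2 and an at least 1.0-fold lower number (0.02 log units; that floor lies within the scatter) from compound 3 to compound 4; the limit leaves it open whether they differ

The compounds shown leave open whether a different group in the same place on the ring, such as an amine or a carboxylic acid, would shift the number beyond the scatter. They also leave open what a longer chain in place of the methoxy would do.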